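Chloro to methoxy on compound 2

A few compounds are considered here, and "the series" means these few. Any claim that something is new, unique, unknown or untested is made for them only; others in the source may bear on it.

Of the compounds shown here, three have been read so far in a functional assay on MCF7 cells (Homo sapiens) for antiproliferative activity, read by MTT assay, with a stated time of 48 h (a lower number here means a stronger inhibitor, a higher number a weaker inhibitor), and only one gives a number. Compound 1 (`O=C(/C=C/c1ccccn1)c1nc2ccccc2s1`) gives > 100000 nM as a limit of the assay. Compound 2 (`OC(/C=C/c1cccc(Cl)c1)c1nc2ccccc2[nH]1`) gives > 100000 nM as a limit of the assay too. Going by the values given here, compound 3 (`O=C(/C=C/c1ccccn1)c1nc2ccccc2[nH]1`) gives 3640 nM as the only numeric reading.

Compound 2 therefore stands at the limit of > 100000 nM in this assay, at which 2 of the 3 values shown sit, and has no number of its own. Any step away from it starts from a limit, not from a known point.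

Compound 4 (`COc1cccc(/C=C/C(O)c2nc3ccccc3[nH]2)c1`) keeps everything in compound 2 except one substituent, with methoxy in place of chloro on an aromatic carbon, meta to a large group. The counted change is methoxy in place of chloro on an aromatic carbon and nothing else in the structure differs.

Among the compounds with values here, no pair of measured compounds covers this change, so its size in this assay cannot be read from data. A small move towards a stronger reading is expected, and no large change. The estimate for this is an at least 1.4-fold lower number from compound 2 to compound 4 (0.15 log units; that floor lies within the scatter) and it stays uncertain at its starting end. For compound 4 the expected value is 70000 nM with an estimated range from 15000 nM to 200000 nM and a reading that is again only a limit remains quite possible.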

Compound 4, half-maximal inhibitory concentration: > 100000 nM
Compound 4: only a limit was reported (the forecaster's own chance of this, stated with the estimate: 55%); at least 1.4-fold (0.15 log units) between middle value and limit.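

No size can be read for the change from compound 2 to compound 4, methoxy in place of chloro on an aromatic carbon, because both compounds stand at the same limit: the limit of > 100000 nM in this assay, at which 3 of the 4 values shown sit.

The compounds shown leave open whether this change shifts the reading at all, and if so in which direction.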